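Swapping azidomethyl for (pyrrolidin-1-yl)carbonyl on the shared core

A few compounds are considered here, and "the series" means these few. Any claim that something is new, unique, unknown or untested is made for them only; others in the source may bear on it.

compound 1 `CC(=O)OC/C1=C/C[C@](C)(CCC=C(C)C)/C=C/[C@@H](OC(=O)C=C(C)C)[C@](C)(O)/C=C/C1=O` gives 4510 nM here
compound 2 `CC(C)=CCC[C@]1(C)/C=C/[C@@H](OC(=O)C=C(C)C)[C@](C)(O)/C=C/C(=O)/C(CN=[N+]=[N-])=C\C1` gives 4890 nM here

Among the measured compounds shown here, in a functional assay on MCF7 cells (Homo sapiens) for antiproliferative activity, read by MTT assay, with a stated time of 48 h (a lower number here means a stronger inhibitor, a higher number a weaker inhibitor), compound 2 gives 4890 nM and stands level with compound 1, the only other measured compound. Next comes compound 3 `CC(C)=CCC[C@]1(C)/C=C/[C@@H](OC(=O)C=C(C)C)[C@](C)(O)/C=C/C(=O)/C(C(=O)N2CCCC2)=C\C1`, which carries (pyrrolidin-1-yl)carbonyl in place of azidomethyl on a double-bonded ring carbon. For the measured compounds named here, one measured step bears on this. Azido in place of acetoxy, on a saturated chain carbon bound to that double-bonded ring carbon, gave a 1.1-fold higher number from compound 1 to compound 2 (0.04 log units; within the scatter) and so stayed within the scatter. A single swap is thin evidence, and the new group is attached differently, so the margin must stay wide. In this assay no step beyond the scatter is expected, and the estimated step is a 1.1-fold higher number from compound 2 to compound 3 (0.05 log units; within the scatter) at most a slight rise. For compound 3 the expected value is 5500 nM, with an estimated range from 2000 nM to 15000 nM overall.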

Compound 3, half-maximal inhibitory concentration: 17200 nM
The estimate for compound 3 lay 3.1-fold (0.50 log units) below the measured number; the whole stated range lies below it.
By their numbers in this assay, from the lowest: compounds 1 and 2 (each within the scatter of the next); then compound 3.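

In this assay, putting (pyrrolidin-1-yl)carbonyl on this double-bonded ring carbon gave a 3.5-fold higher number from compound 2 to compound 3 (0.55 log units; beyond the scatter), and measured against the acetoxymethyl group it gave a 3.8-fold higher number from compound 1 to compound 3 (0.58 log units; beyond the scatter) on the same core. Among the compounds shown here, the earlier swap of acetoxy for azido stayed within the scatter, so this is the first sign that the position does not accept every group alike. Nothing measured here explains the rise.

The change removes the saturated chain carbon and adds a pyrrolidine ring at once, so the compounds shown cannot tell these two effects apart; a (pyrrolidin-1-yl)methyl group, which keeps that carbon, or a carboxylic acid, which has no ring, would help separate them. On these data alone, whether any group at this carbon can bring the number below those of compounds 1 and 2 also remains open.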